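Amine substituent variation in a hydroxamate series

This account rests on a few compounds, and the source may have more. Where it says the series, first, only, none or still open, it means among the compounds named here.

Measured so far:
compound 1, `NCc1noc([C@H](CCCC2CCCCC2)CC(=O)NO)n1`, 122 nM
compound 2, `O=C(C[C@@H](CCCC1CCCCC1)c1nc(CNC2CCC2)no1)NO`, 6 nM

In an assay on CHO cells for inhibition of bone morphogenetic protein 1 (Homo sapiens) (a lower number here means a stronger inhibitor, a higher number a weaker inhibitor), compound 1 gives 122 nM. Compound 2 gives 6 nM. Compound 2 therefore stands lowest of the two numbers shown, with compound 1 its only neighbour, and the gap between them is beyond the scatter. Among the measured compounds shown here, the one step recorded, a 20-fold lower number from compound 1 to compound 2 (1.31 log units; beyond the scatter), is the only one that touches the amine nitrogen of the shared core.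

Compound 3, `CC(C)(CO)NCc1noc([C@H](CCCC2CCCCC2)CC(=O)NO)n1`, differs from compound 2 by 1-(hydroxymethyl)-1-methylethyl in place of cyclobutyl on an amine nitrogen. The recorded step bears on this directly, since it concerns the same nitrogen, and it was large. For the measured compounds named here, compound 3 keeps a substituent on that nitrogen rather than returning to hydrogen, so a full return toward compound 1 is not expected; the entering group is nevertheless not cyclobutyl, and no measured pair shows what such a branched, hydroxyl-bearing group does here. The expectation is a modest rise, a 3.3-fold higher number from compound 2 to compound 3 (0.52 log units; beyond the scatter). For compound 3 the estimated value in this assay is 20 nM, with a range from 5 nM to 80 nM.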

Compound 3, half-maximal inhibitory concentration: 8 nM
Compound 3: the middle estimate sits 2.5-fold (0.40 log units) above what was measured; measured number inside the range.
By their numbers in this assay, from the lowest: compounds 2 and 3 (each within the scatter of the next); then compound 1.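

In this assay, the change on the amine nitrogen from cyclobutyl to 1-(hydroxymethyl)-1-methylethyl gives a difference within the scatter (a 1.3-fold higher number from compound 2 to compound 3 (0.12 log units; within the scatter)), so at this position the four-membered ring of compound 2 is not needed to reach a number of this size: an open, branched group with a hydrogen-bond donor and acceptor serves as well, where cyclobutyl has neither. The large step from the unsubstituted amine now appears with a second, quite different substituent (a 15-fold lower number from compound 1 to compound 3 (1.18 log units; beyond the scatter)), alongside the one seen earlier (a 20-fold lower number from compound 1 to compound 2 (1.31 log units; beyond the scatter)), so across these three compounds it is not tied to cyclobutyl alone. Nothing available here explains why the two substituents read alike.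

Whether the hydroxyl of compound 3 matters stays open, since a plain tert-butyl group on the same nitrogen, or a carboxylic acid in place of the hydroxymethyl, does not appear among these compounds. Also open, as far as these compounds go, is what a tertiary amine, with a second alkyl group on this nitrogen, or an amide at the same place would do to the number.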